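The source may report more compounds than this note shows. Statements on the series, on what has been measured and on what is new or still open speak of the compounds shown alone.

Working notes on the series. Compound 1 `N[C@]1(C(=O)O)[C@H]2[C@@H](C[C@H]1OCc1ccccc1)[C@]2(F)C(=O)O` carries an unsubstituted phenyl on a saturated chain carbon bound to an oxygen on a saturated carbon, and in an assay on CHO cells for binding affinity to metabotropic glutamate receptor 2 (Rattus norvegicus) (a higher number here means a weaker inhibitor, a lower number a stronger inhibitor), compound 1 gives 7.14 nM. Compound 2 `N[C@]1(C(=O)O)[C@H]2[C@@H](C[C@H]1OCc1cccc(F)c1F)[C@]2(F)C(=O)O` gives 4.25 nM and compound 3 `N[C@]1(C(=O)O)[C@H]2[C@@H](C[C@H]1OCc1cc(F)ccc1F)[C@]2(F)C(=O)O` gives 14.4 nM. Among the three numbers compound 3 gives the highest; the gap to compound 1 is within the scatter, and the step of a 3.4-fold higher number from compound 2 to compound 3 (0.53 log units; beyond the scatter) is the only one beyond it. The other steps, a 1.7-fold lower number from compound 1 to compound 2 (0.23 log units; within the scatter) and a 2.0-fold higher number from compound 1 to compound 3 (0.30 log units; within the scatter), show that the ring substitution pattern at this place moves the number only modestly in either direction.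

Compound 4 `N[C@]1(C(=O)O)[C@H]2[C@@H](C[C@H]1OCc1c(Cl)cccc1Cl)[C@]2(F)C(=O)O` differs from compound 3 by 2,6-dichlorophenyl in place of 2,5-difluorophenyl on a saturated chain carbon bound to an oxygen on a saturated carbon. Among the compounds with values here, no measured step exchanges fluorine for chlorine or tests the substitution pattern that enters here, so the bearing of the three steps is indirect; the largest of them, a 3.4-fold higher number from compound 2 to compound 3 (0.53 log units; beyond the scatter), sets the scale expected for a change of ring substituents here. For compound 4 a step no larger than that, in no firm direction, is expected: a 1.0-fold higher number from compound 3 to compound 4 (0.02 log units; within the scatter). The estimate for compound 4 is 15 nM, with a range from 5 nM to 45 nM.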

Compound 4, inhibition constant: 4.3 nM
Beside the measured number, compound 4's estimate is 3.5-fold (0.54 log units) above it, and the stated range ends above it.
By their numbers in this assay, from the lowest: compounds 2, 4, 1 and 3 (each within the scatter of the next, the first and the last beyond it).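

Chlorine on the ring appears here for the first time, and 2,6-dichlorophenyl is accommodated at this position in this assay: a 1.7-fold lower number from compound 1 to compound 4 (0.22 log units; within the scatter) and a 1.0-fold higher number from compound 2 to compound 4 (0.01 log units; within the scatter). Against the 2,5-difluorophenyl group the change is larger, a 3.3-fold lower number from compound 3 to compound 4 (0.52 log units; beyond the scatter), so compound 3 now lies beyond the scatter of both compound 2 and compound 4 while remaining within it of compound 1. No supporting data are available to explain this difference among the ring groups.

In the step to compound 4, the halogen and the substitution pattern change together, so 2,6-difluorophenyl is the group that would separate them. Also open, from the compounds shown here alone, is how a methoxy group, a nitrile or an amine on the ring, or a longer chain at the saturated chain carbon, would fare here.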